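This account rests on a few compounds, and the source may have more. Where it says the series, first, only, none or still open, it means among the compounds named here.

Measured so far in a functional assay on MV4-11 cells (Homo sapiens) for inhibition, read by resazurin assay, with a stated time of 72 h; a higher number here means a weaker inhibitor of growth, a lower number a stronger inhibitor of growth:
compound 1 `Cc1ccsc1-c1cncc(Cl)c1N1CCC2(CCNC2=O)CC1`: 910 nM
compound 2 `Cc1ccc(-c2cncc(Cl)c2N2CCC3(CCNC3=O)CC2)s1`: 650 nM
compound 3 `CC(C)(C)OC(=O)N1CCN(Cc2ccc(-c3cncc(Cl)c3N3CCC4(CCNC4=O)CC3)s2)CC1`: 5150 nM

Compound 1 stands second highest of the three numbers, with compound 2 nearest and compound 3 furthest. Among the compounds with values here, the only one-place step measured is a 1.4-fold lower number from compound 1 to compound 2 (0.15 log units; within the scatter), the exchange of 3-methylthiophen-2-yl for 5-methylthiophen-2-yl. Compound 3 carries a much larger substituent and gives the highest number of the three. Compound 4 `O=Cc1cscc1-c1cncc(Cl)c1N1CCC2(CCNC2=O)CC1` differs from compound 1 by 4-formylthiophen-3-yl in place of 3-methylthiophen-2-yl on an aromatic carbon. Within the data shown here, only the step from compound 1 to compound 2 bears on this, and it lay within the scatter; the change here is likewise a small alteration of the thiophene, so no step beyond the scatter is expected in this assay. Compound 4 is therefore estimated at 1100 nM, with a range from 400 nM to 3000 nM. The step expected in this assay is a 1.2-fold higher number from compound 1 to compound 4 (0.08 log units; within the scatter).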

Compound 4, concentration for 50% growth inhibition: 27100 nM
Beside the measured number, compound 4's estimate is 25-fold (1.39 log units) below it, outside the stated range (above it).
By their numbers in this assay, from the lowest: compounds 2 and 1 (each within the scatter of the next); then compound 3; then compound 4.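

In this assay the replacement on this aromatic carbon, ortho to a large group, is not neutral: 4-formylthiophen-3-yl gives a 30-fold higher number from compound 1 to compound 4 (1.47 log units; beyond the scatter) and also a 42-fold higher number from compound 2 to compound 4 (1.62 log units; beyond the scatter) in the same direction. Moving the methyl on the thiophene gave only a 1.4-fold lower number from compound 1 to compound 2 (0.15 log units; within the scatter) and so did not reveal that this position can respond so strongly. Nothing at hand bears on the cause of this loss.

Formyl and the shift from a thiophen-2-yl to a thiophen-3-yl attachment change together here, so their separate contributions stay open. A 4-methylthiophen-3-yl group or a hydroxymethyl in place of the formyl would address this.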